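Side chain and configuration in the benzylamino amide series

The source may report more compounds than this note shows. Statements on the series, on what has been measured and on what is new or still open speak of the compounds shown alone.

- compound 1 `CNC(=O)[C@H](CO)NCc1ccc(OCc2ccccc2)cc1`: 15 mg/kg
- compound 2 `CNC(=O)[C@H](NCc1ccc(OCc2ccccc2)cc1)C(C)C`: 112 mg/kg
- compound 3 `CNC(=O)[C@@H](NCc1ccc(OCc2ccccc2)cc1)C(C)C`: 55.4 mg/kg

In a functional assay on the whole organism with Mus musculus as the target (on this read-out higher numbers stand for an effect only at larger amounts of compound and lower numbers for an effect already at smaller amounts), compound 3 gives 55.4 mg/kg as the second highest of the three numbers, below compound 2 and above compound 1. Compound 4 `CC[C@@H](NCc1ccc(OCc2ccccc2)cc1)C(N)=O` differs by 1-carbamoylpropyl in place of 2-methyl-1-(methylcarbamoyl)propyl on an amine nitrogen, with 1-carbamoylpropyl in place of 2-methyl-1-(methylcarbamoyl)propyl on an amine nitrogen. Within the data shown here, two measured steps bear on this. Isopropyl in place of hydroxymethyl gave a 3.7-fold higher number from compound 1 to compound 3 (0.57 log units; beyond the scatter), so losing isopropyl may modestly lower the number. Compound 4 is drawn R like compound 2, and a 2.0-fold lower number from compound 2 to compound 3 (0.31 log units; beyond the scatter), tied to the fact that compounds 2 and 3 differ only in the configuration as drawn, points the other way. Among the measured compounds shown here, no measured step covers the lost amide methyl. These modest pulls should roughly cancel, so no step beyond the scatter is expected. The expected change is a 1.2-fold lower number from compound 3 to compound 4 (0.09 log units; within the scatter). For compound 4 the estimated value is 45 mg/kg, with an expected range of 18 mg/kg to 110 mg/kg.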

Compound 4, dose for half-maximal effect: 55 mg/kg
Compound 4: the middle estimate sits 1.2-fold (0.09 log units) below what was measured; low and high end bracket the measured number.
By their numbers in this assay, from the lowest: compound 1; then compounds 4 and 3 (each within the scatter of the next); then compound 2.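

In this assay, 1-carbamoylpropyl in place of 2-methyl-1-(methylcarbamoyl)propyl on the amine nitrogen gives no readable shift across a change of drawn configuration: a 1.0-fold lower number from compound 3 to compound 4 (0.00 log units; within the scatter). With the drawn R configuration kept, the same exchange gives a 2.0-fold lower number from compound 2 to compound 4 (0.31 log units; beyond the scatter), a reading that configuration does not confound, whereas the isopropyl pair isolates configuration alone: the fact that compounds 2 and 3 differ only in the configuration as drawn. The hydroxymethyl side chain remains apart, with a 3.7-fold higher number from compound 1 to compound 4 (0.56 log units; beyond the scatter), so losing isopropyl and the amide methyl together does not recover its value.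

From the compounds shown here alone, how the lost branch and lost amide methyl divide the step remains open, as does the effect of the opposite configuration on 1-carbamoylpropyl. Going by these compounds, a longer chain, or an amine or carboxylic acid on this side chain, also remains open.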